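The compounds below may be only part of what the source reports. "The series", "measured", "known", "first", "only" and "open" are said of these compounds alone.

Within the data shown here, compound 2, `COC(=O)C(C)(C)Nc1cc(CS(=O)(=O)/C=C/c2c(OC)cc(OC)cc2OC)ccc1OC`, is one of two compounds measured in a functional assay on K562 cells (Homo sapiens) for cytotoxicity, read by trypan blue exclusion, with a stated time of 96 h; on this read-out lower numbers stand for stronger inhibition and higher numbers for weaker inhibition. Among the measured compounds shown here, compound 1, `COc1cc(OC)c(/C=C/S(=O)(=O)Cc2ccc(F)c(N)c2)c(OC)c1`, gives 2500 nM in that assay, while compound 2 gives 800 nM, the lower of the two numbers; the gap between them lies beyond the scatter, and no single-point step connects these two structures.

Compound 3, `COc1cc(OC)c(/C=C/S(=O)(=O)Cc2ccc(OC)c(NC(C(=O)O)c3ccc(F)cc3)c2)c(OC)c1`, has not been measured in this assay. It differs from compound 2 in one place: carboxy(4-fluorophenyl)methyl in place of 1-(methoxycarbonyl)-1-methylethyl on a nitrogen on an aromatic ring. For the measured compounds named here, no measured pair shows what this change does, so the expectation rests on compound 2 alone.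

Going by the values given here, the step of a 1.5-fold higher number from compound 2 to compound 3 (0.18 log units; within the scatter) is expected to be modest, leaning toward a somewhat higher number, because the value of compound 2, 800 nM, is the only anchor and the change is larger than any step seen here. For compound 3 the expected value in this assay is 1200 nM, with a range from 400 nM to 4000 nM.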

Compound 3, half-maximal inhibitory concentration: 80 nM
For compound 3 the middle estimate is 15-fold (1.18 log units) above the measured one; the whole stated range lies above it.
By their numbers in this assay, from the lowest: compound 3; then compound 2; then compound 1.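

Carboxy(4-fluorophenyl)methyl in place of 1-(methoxycarbonyl)-1-methylethyl on a nitrogen on an aromatic ring gives a 10-fold lower number from compound 2 to compound 3 (1.00 log units; beyond the scatter) in this assay. Among these compounds, this is the first one-place comparison, and it shows that the number at this position depends strongly on the group the nitrogen carries and that a larger group with a six-membered aromatic ring is compatible with a low number. The data shown offer no measured explanation for this shift.

Among the compounds shown here, the single step changes several features at once, so it leaves open whether the carboxylic acid, the 4-fluorophenyl ring or the loss of the two methyl groups accounts for it. As far as these compounds go, how a methyl ester of compound 3, a plain phenyl ring in place of 4-fluorophenyl, or an amine in place of the carboxylic acid would read also remains open.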